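Ethyl in place of 3,4-dichlorophenyl on the ring nitrogen

The source may report more compounds than this note shows. Statements on the series, on what has been measured and on what is new or still open speak of the compounds shown alone.

- Compound 1 `COc1cccc(N2CCN(c3c(CO)c(=O)oc4ccccc34)CC2)c1`: > 50000 nM (a limit)
- Compound 2 `O=c1oc2ccccc2c(N2CCN(c3ccc(Cl)c(Cl)c3)CC2)c1CO`: > 50000 nM (a limit)

In a toxicity assay on HEK-293T cells (Homo sapiens) for inhibition, read by MTT assay, with a stated time of 24 h (on this read-out higher numbers stand for lower toxicity in this test and lower numbers for higher toxicity in this test), compound 2 gives > 50000 nM, which is a limit of the assay and not a number. It shares that position with compound 1, so the record so far reads (the limit of > 50000 nM in this assay, at which 2 of the 2 values shown sit). Going by the values given here, the one measured step is a step that the two limits leave unreadable from compound 1 to compound 2, and it brought 3,4-dichlorophenyl in place of 3-methoxyphenyl on the same nitrogen.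

Compound 3 `CCN1CCN(c2c(CO)c(=O)oc3ccccc23)CC1` has not yet been measured. It carries ethyl in place of 3,4-dichlorophenyl on an amine nitrogen in a ring. Among the compounds with values here, no measured step removes the ring from this position, so no step size can be carried over, and the expectation is loose. Compound 2 gives > 50000 nM, so the starting point is itself a limit. With no sign of toxicity in either measured compound, no step beyond the scatter is expected. The expected step is a number no higher from compound 2 to compound 3 (the limit leaves the size open). For compound 3 the estimated value is 50000 nM, with an expected range of 20000 nM to 100000 nM.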

Compound 3, half-maximal cytotoxic concentration: > 50000 nM
Compound 3: a limit, no number; the forecaster's own chance of this, stated with the estimate: 80%; the middle value lies on the limit itself.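

No step can be read from compound 2 to compound 3 or from compound 1 to compound 3, because all three compounds rest on the same limit, which is not a number: the limit of > 50000 nM in this assay, at which 3 of the 3 values shown sit. The compounds shown leave open what number each one would give, and whether the group on the ring nitrogen affects toxicity at all.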